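The compounds below may be only part of what the source reports. "The series", "measured", "known", "first", "only" and "open" are said of these compounds alone.

Three compounds have been measured in a functional assay on A549 cells (Homo sapiens) for antiproliferative activity, with a stated time of 72 h, tested at 10 ug/mL; on this read-out lower numbers stand for a weaker effect and higher numbers for a stronger effect at the one concentration tested:

compound 1 `O=c1[nH]nc2n(c1=O)CCN2c1ccccc1` gives 0%
compound 2 `N=c1c(=O)[nH]nc2n1CCN2c1cccc(Cl)c1` gives 36%
compound 3 `N=c1c(=O)[nH]nc2n1CCN2c1ccccc1` gives 7%

Compound 3 and compound 2 share one core and differ in a single place: chloro in place of hydrogen on an aromatic carbon. That change made a step of a number 29 percentage points higher from compound 3 to compound 2 (beyond the scatter). Compound 1 rests on another core; the difference between the two cores is not broken down here. Compound 1 has the lowest of the three numbers, but its gap to compound 3 lies within the usual scatter, so those two cannot be told apart; only its gap to compound 2 lies beyond the scatter.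

Compound 4 `O=c1[nH]nc2n(c1=O)CCN2c1cccc(Cl)c1` has not yet been measured in this assay. It comes from compound 1 by the same change: chloro in place of hydrogen on an aromatic carbon. Both changes sit at the same place, on a six-membered aromatic ring of carbon only, so this is the same change carried onto the other core. Going by the values given here, the step from compound 3 to compound 2 is the only example of it, and the expectation rests on that alone. Compound 4 is expected to show a step of a number 20 percentage points higher from compound 1 to compound 4 (beyond the scatter) because the same change gave a number 29 percentage points higher from compound 3 to compound 2 (beyond the scatter) on the other core. A somewhat smaller step than that is estimated. The two cores differ, and a single example is a thin basis. Compound 4 is therefore estimated at 20%, with a range from 0% to 45%.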

Compound 4, a percentage reported as inhibition, at one concentration (the size of the read-out at that concentration, not a potency): 0%
The estimate for compound 4 lay 20 percentage points above the measured number; the measured number falls inside the stated range.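

In this assay, chloro in place of hydrogen on an aromatic carbon gave no change at the digits printed from compound 1 to compound 4 (within the scatter), so the rise seen on the other core did not appear on the core of compound 1. The same change therefore behaved differently on the two cores, and the difference is larger than ordinary scatter between measurements: the same change on two cores in this assay, a number 29 percentage points higher (beyond the scatter) from compound 3 to compound 2 and no change at the digits printed (within the scatter) from compound 1 to compound 4, 29 percentage points apart, beyond the scatter of two such steps This shows that, for these two pairs, a step measured on one core could not be carried onto the other, but with only one pair on each core it does not show why the cores differ, nor whether the same would hold for other groups or in other series.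

The compounds shown carry only hydrogen or chloro on the aromatic ring, and the chloro sits at only one place, so it remains open whether fluoro, methoxy or trifluoromethyl there would also separate the two cores. Going by these compounds, it is equally open whether a quite different group, such as an amine or a carboxylic acid, could raise the number on the core of compound 1 at all.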